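Mirror-image change at a chain stereocentre in a kinase inhibitor

The source may hold more compounds than are shown below. What is called first, only, known or untested is meant among the compounds shown, and "the series" means these compounds.

Measured so far:
Compound 1, `C[C@@H](O)CNc1cc(Oc2ccc(NC(=O)Nc3cccc(C(F)(F)F)c3)cc2)ncn1`: 63 nM
Compound 2, `CNc1cc(Oc2ccc(NC(=O)Nc3cccc(C(F)(F)F)c3)c(F)c2F)ncn1`: 20 nM

Both compounds were tested in an assay on isolated protein for inhibition of serine/threonine-protein kinase TNNI3K (Homo sapiens); on this read-out lower numbers stand for stronger inhibition and higher numbers for weaker inhibition. On these numbers compound 1 stands highest of the two: compound 2 gives the lower number, and the gap between them lies beyond the usual scatter. For the measured compounds named here, no single-change step between the two is worked out here, so their values are simply set side by side.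

The new compound is compound 3, `C[C@H](O)CNc1cc(Oc2ccc(NC(=O)Nc3cccc(C(F)(F)F)c3)cc2)ncn1`. It differs from compound 1 only in this way: the two compounds have the same atoms and bonds and differ only in configuration as drawn: 1 of 1 stereo elements differ; a stereocentre at a saturated chain carbon is drawn R in compound 1 and S in compound 3. No atom leaves and none enters; the same groups are joined in the same way, and only the handedness at that one chain carbon is reversed.

Going by the values given here, no pair of measured compounds shows how such a change in handedness alone moves the result in this assay, so there is no measured step to lean on. Under that uncertainty, the expectation is a step from compound 1 to compound 3 of a 1.1-fold higher number from compound 1 to compound 3 (0.05 log units; within the scatter), not clearly beyond the scatter in either direction. The value expected for compound 3 is 70 nM, with a range from 20 nM to 250 nM.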

Compound 3, half-maximal inhibitory concentration: 32 nM
Beside the measured number, compound 3's estimate is 2.2-fold (0.34 log units) above it, and the stated range covers the measured number.
By their numbers in this assay, from the lowest: compounds 2, 3 and 1 (each within the scatter of the next, the first and the last beyond it).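

In this assay, for the compounds shown here, reversing the handedness at this saturated chain carbon gives the first direct reading of what the stereocentre contributes to the result: a 2.0-fold lower number from compound 1 to compound 3 (0.29 log units; within the scatter). The earlier compounds shown here could not show this, and the reading is that the R and S forms of this chain cannot be told apart with confidence on this read-out, so in this pair the position accepts either configuration without a gap beyond the scatter. The comparison is a clean one because no other feature separates the two compounds, so any real gap, however small, would belong to the stereocentre alone: the fact that compounds 1 and 3 differ only in the configuration as drawn

A repeat of the measurements would be needed to say whether a small real preference for the S form lies hidden within the scatter, and these two mirror-image compounds cannot settle that. From the compounds shown here alone, it also stays open whether handedness at this carbon would matter just as little in a longer chain, or in a chain carrying an amine in place of the hydroxyl group.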